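The compounds below may be only part of what the source reports. "The series", "measured", "known", "first", "only" and "open" are said of these compounds alone.

Measured so far:
- compound 1, `O=c1oc2ccccc2n1CCN1CCN(c2ccccc2)CC1`: > 50 mg/kg
- compound 2, `O=c1oc2cccnc2n1CN1CCN(c2ccc(F)cc2)CC1`: 3.5 mg/kg

Both compounds were tested in a functional assay on the whole organism with Mus musculus as the target; on this read-out lower numbers stand for an effect already at smaller amounts and higher numbers for an effect only at larger amounts of compound. Compound 1 gives > 50 mg/kg in this assay, which is a limit of the assay and not a number. Among the compounds with values here, compound 2 gives 3.5 mg/kg in this assay, and it is the only real number among the two values; the other value sits at the limit of > 50 mg/kg in this assay, at which 1 of the 2 values shown sits. Within the data shown here, with no pair of measured compounds differing in a single place, no measured step is available to show how one change in structure moves this read-out.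

Compound 3, `O=c1oc2cccnc2n1CN1CCN(c2ccc(Cl)cc2)CC1`, has not yet been measured. It differs from compound 2 in one place: chloro in place of fluoro on an aromatic carbon. On a change this small, chloro in place of fluoro on an aromatic carbon, the expectation is no step beyond the usual scatter of this assay in either direction. The step expected from this change, no change at the digits printed from compound 2 to compound 3 (within the scatter), is therefore estimated to stay within the scatter. Compound 3 is expected to give about 3.5 mg/kg in this assay, with the estimate ranging from 1.5 mg/kg to 8 mg/kg.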

Compound 3, dose for half-maximal effect: 10.6 mg/kg
Beside the measured number, compound 3's estimate is 3.0-fold (0.48 log units) below it, and the stated range ends below it.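

In this assay, going from 4-fluorophenyl to 4-chlorophenyl gives a 3.0-fold higher number from compound 2 to compound 3 (0.48 log units; beyond the scatter), so a larger dose of the chloro compound is needed for the same effect. Within the data shown here, this is the first single-place comparison in the set, and it shows that this position, on the aromatic ring and para to a large group, is not indifferent to the atom it carries: exchanging one heavy atom for another, with no change in rings, hydrogen-bond donors, hydrogen-bond acceptors or net charge, moves the read-out modestly but beyond the usual scatter. Nothing among the data shown accounts for this step.

As far as these compounds go, this single pair gives no trend, so it remains open whether plain hydrogen, a methyl, a methoxy or an amine at the same position would give a lower or a higher number than fluoro or chloro. From the compounds shown here alone, it also remains open whether the same exchange would move the read-out similarly on another core, or with a longer chain joining the core to the piperazine-bearing part of the molecule.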